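This account rests on a few compounds, and the source may have more. Where it says the series, first, only, none or still open, it means among the compounds named here.

The measured compounds are:
compound 1 `Cc1nc2c3ccccc3ccc2c2nc3c(ccc4ccccc43)c(-c3ccccc3Cl)c12`, which gives 170 ug/mL in a functional assay, with a stated time of 90 s; on this read-out higher numbers stand for weaker inhibition and lower numbers for stronger inhibition;
compound 2 `Cc1nc2c3ccccc3ccc2c2nc3c(ccc4ccccc43)c(-c3ccccc3S)c12`, which gives 158 ug/mL in this assay;
compound 3 `Cc1nc2c3ccccc3ccc2c2nc3c(ccc4ccccc43)c(-c3cccc([N+](=O)[O-])c3)c12`, which gives 157 ug/mL in this assay.

Compound 2 stands second highest of these three numbers, but its neighbours sit very close: a 1.1-fold lower number from compound 1 to compound 2 (0.03 log units; within the scatter) and a 1.0-fold lower number from compound 2 to compound 3 (0.00 log units; within the scatter) are both within the scatter, as is a 1.1-fold lower number from compound 1 to compound 3 (0.03 log units; within the scatter), so the three compounds cannot be told apart here. Compound 4 `Cc1nc2c3ccccc3ccc2c2nc3c(ccc4ccccc43)c(C)c12` is not yet measured. Its change from compound 2 is methyl in place of 2-sulfanylphenyl on an aromatic carbon. Among the measured compounds shown here, none of the measured steps bears on this directly: each of them keeps a substituted phenyl ring at this position and only alters what sits on it, and every one of those alterations left the number essentially unchanged. Whether removing the whole ring matters is therefore unknown, and my expectation is that the step from compound 2 to compound 4 is small, a 1.1-fold higher number from compound 2 to compound 4 (0.06 log units; within the scatter), with a wide range to cover the lack of evidence. For compound 4 I estimate 180 ug/mL in this assay, between 90 ug/mL and 360 ug/mL.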

Compound 4, half-maximal inhibitory concentration: 195 ug/mL
Compound 4: middle estimate off by 1.1-fold (0.03 log units), on the low side; the measured number falls inside the stated range.
By their numbers in this assay, from the lowest: compounds 3, 2, 1 and 4 (each within the scatter of the next).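

In this assay, the whole substituted phenyl ring at this position can be swapped for methyl with no readable effect (a 1.2-fold higher number from compound 2 to compound 4 (0.09 log units; within the scatter); a 1.2-fold higher number from compound 3 to compound 4 (0.09 log units; within the scatter); a 1.1-fold higher number from compound 1 to compound 4 (0.06 log units; within the scatter)). The earlier compounds shown here varied only what sat on the ring, whereas these steps remove the ring itself, so across these four compounds neither the ring nor its sulfanyl, nitro or chloro group shows a measurable part in this read-out. Nothing measured here offers an explanation for this flat result.

Still open, as far as these compounds go, is whether a different kind of group on this aromatic carbon, such as an amine, a carboxylic acid or a longer alkyl chain, would shift the number beyond the scatter. Also open, from the compounds shown here alone, is whether changes elsewhere on the shared core would do so, as all four compounds carry that core unchanged.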